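The compounds below may be only part of what the source reports. "The series", "measured", "known", "first", "only" and "open" are said of these compounds alone.

Measured compounds:

Compound 1, `CC(C)[C@H](NC(=O)COc1cccc2ccccc12)C(=O)N[C@@H](CC(=O)O)C(=O)COC(=O)c1c(Cl)cccc1Cl`: in a functional assay on Jurkat cells (Homo sapiens) (on this read-out higher numbers stand for weaker inhibition and lower numbers for stronger inhibition), compound 1 gives 10600 nM.

Compound 2, `CC(C)[C@H](NC(=O)COc1cccc2ccccc12)C(=O)N[C@@H](CC(=O)O)C(=O)COc1ccccc1F`: for compound 2 this assay reports only a limit, > 100000 nM.

Compound 2 therefore stands at the edge of what this assay can report, (the limit of > 100000 nM in this assay, at which 1 of the 2 values shown sits), so its true number is not known, only that it lies beyond the range measured. Going by the values given here, the single measured step leading to it is an at least 9.4-fold higher number from compound 1 to compound 2 (0.97 log units; beyond the scatter), a weakening that is clearly beyond the scatter but whose exact size is hidden by the limit.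

Compound 3, `CC(C)[C@H](NC(=O)COc1cccc2ccccc12)C(=O)N[C@@H](CC(=O)O)C(=O)COc1cc(F)c(F)cc1F`, differs from compound 2 by 2,4,5-trifluorophenyl in place of 2-fluorophenyl on an oxygen on a saturated carbon. Among the compounds with values here, no measured step tests this kind of change: the only step known swaps a whole group for another and says nothing about adding fluorine to a ring that is already present. With compound 2 already at the limit, any further weakening could not be seen, and a strengthening would have to be large to show up as a number at all. Compound 3 is therefore expected to sit close to compound 2, with a number no higher from compound 2 to compound 3 (the limit leaves the size open) amounting to no step beyond the scatter. The estimate for compound 3 in this assay is 100000 nM, within a range from 30000 nM to 300000 nM, and most likely reported again only as a limit.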

Compound 3, half-maximal inhibitory concentration: 39300 nM
Beside the measured number, compound 3's estimate is 2.5-fold (0.41 log units) above it; measured number inside the range.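

This position responds to more than the exchange of one whole group for another: it also responds to a change on a phenyl ring that stays in place. In this assay, 2,4,5-trifluorophenyl in place of 2-fluorophenyl on the oxygen gives an at least 2.5-fold lower number from compound 2 to compound 3 (0.40 log units; beyond the scatter), a move towards stronger inhibition, but compound 2 has only a limit, so the true size of this step stays hidden: the limit of > 100000 nM in this assay, at which 1 of the 3 values shown sits. The 2,4,5-trifluorophenyl group still does not restore the level of the (2,6-dichlorophenyl)carbonyl group at this place, with a 3.7-fold higher number from compound 1 to compound 3 (0.57 log units; beyond the scatter), so the new ring recovers part of the loss seen with 2-fluorophenyl, but not all of it.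

The compounds shown leave open which of the fluorines in 2,4,5-trifluorophenyl accounts for the change, as the only two fluorinated rings here differ at more than one ring carbon. They also leave open how a 2,6-dichlorophenyl group attached directly to the oxygen, without the carbonyl, or a phenyl ring carrying a methoxy group would compare at this place.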